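Amide-linked aminothiazoles: from compound 3 to compound 4

A few compounds are considered here, and "the series" means these few. Any claim that something is new, unique, unknown or untested is made for them only; others in the source may bear on it.

Of the compounds shown here, three have been measured in an assay on isolated protein for inhibition of Rho-associated protein kinase 2 (Homo sapiens), read by ELISA, with a stated time of 30 min, tested at 10 uM, in the presence of a further agent that is not named here; a higher number here means more inhibition at the concentration tested (going by the name of the read-out), a lower number less inhibition: compound 1 `CN(C)C(=O)Cc1sc(NC(=O)C2COc3ccccc3O2)nc1-c1ccncc1` gives 56.9%; compound 2 `O=C(Nc1nc(-c2ccncc2)c(CN2CCCCC2)s1)c1ccncc1` gives 48.2%; compound 3 `CN1CCN(Cc2sc(NC(=O)c3cccnc3)nc2-c2cccnc2)CC1` gives 32.1%.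

Compound 3 has the lowest of the three numbers. Its nearest neighbour is compound 2, whose value lies higher by a margin beyond the usual scatter, and compound 1 stands higher still, again beyond the scatter. Compound 3 therefore has the lowest inhibition in this assay of the three on the numbers shown. Among the measured compounds shown here, no two measured compounds differ in only one place, so no single step between them can be read off, and nothing measured yet tells how a change at the saturated chain carbon of compound 3 moves the read-out.

Compound 4 `CC(C)N(C)Cc1sc(NC(=O)c2cccnc2)nc1-c1cccnc1` is the next compound in this series. It differs from compound 3 in one place: isopropyl(methyl)amino in place of 4-methylpiperazin-1-yl on a saturated chain carbon bound to an aromatic carbon. For the measured compounds named here, since no comparable step has been measured, the expected step of a number 3.1 percentage points lower from compound 3 to compound 4 (within the scatter) is a small one, perhaps slightly downward, but none beyond the scatter. On that basis compound 4 is estimated to give 29%, with a range from 12% to 48%.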

Compound 4, a percentage reported as inhibition, at one concentration (the size of the read-out at that concentration, not a potency): 38.1%
Beside the measured number, compound 4's estimate is 9.1 percentage points below it, within the range that was stated.
By their numbers in this assay, from the lowest: compounds 3 and 4 (each within the scatter of the next); then compounds 2 and 1 (each within the scatter of the next).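

In this assay, among the compounds shown here, the change of isopropyl(methyl)amino for 4-methylpiperazin-1-yl on a saturated chain carbon bound to an aromatic carbon gives the first step that can be read at one place, a number 6 percentage points higher from compound 3 to compound 4 (within the scatter), and it stays inside the usual scatter. At this position, then, a group with no ring and fewer heavy atoms, with one hydrogen-bond acceptor fewer, reads the same within the scatter as the six-membered non-aromatic ring it replaces, so neither the ring nor the second ring nitrogen is shown to matter for the read-out in this pair. Nothing at hand indicates why the read-out behaves in this way at this position.

On these data alone, this is a single step on a single pair, so whether the same change would read alike on the core of compound 1 or compound 2 remains open. Equally open, as far as these compounds go, is how the read-out would respond at this carbon to a morpholin-4-yl group, a primary amine, a carboxylic acid or a longer chain between the amine nitrogen and the core.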